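This account rests on a few compounds, and the source may have more. Where it says the series, first, only, none or still open, it means among the compounds named here.

Compound 1 `CCCCCCCCCCCCCCCCCCNC(=O)[C@@H](N)[C@@H](C)O` carries a free amine on the shared core; compound 2 `CCCCCCCCCCCCNC(=O)[C@@H](NC(=O)c1ccco1)[C@@H](C)O` and compound 3 `CCCCCCCCCCCCCCNC(=O)[C@@H](NC(=O)c1ccco1)[C@@H](C)O` carry the same acyl group on that nitrogen and differ from each other only in chain length. In a functional assay on HepG2 cells (Homo sapiens) for cytotoxicity, read by MTT assay, with a stated time of 48 h (a higher number here means a weaker inhibitor, a lower number a stronger inhibitor), compound 1 gives 44500 nM. In this assay compound 2 gives 147000 nM. Compound 3 reaches only (the limit of > 400000 nM in this assay, at which 1 of the 3 values shown sits), so in this assay compound 3 is known as > 400000 nM and not as a number. That leaves an at least 2.7-fold higher number from compound 2 to compound 3 (0.43 log units; beyond the scatter), a change described as ethyl in place of hydrogen on a saturated chain carbon, ten or more bonds along the chain from an amide-type nitrogen.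

Compound 4 `CCCCCCCCCCCCCCCCCCNC(=O)[C@@H](NC(=O)c1ccco1)[C@@H](C)O` differs from compound 3 by butyl in place of hydrogen on a saturated chain carbon, ten or more bonds along the chain from an amide-type nitrogen, a longer extension in the same direction. Going by the values given here, the only measured step that bears on it is an at least 2.7-fold higher number from compound 2 to compound 3 (0.43 log units; beyond the scatter), which moved the number upward to the limit. Compound 1 shares the chain length of compound 4 but lacks the acyl group, so its value does not settle the question. Compound 4 is therefore expected to sit at or beyond the limit, with an estimate of 600000 nM and a range from 200000 nM to 2000000 nM. From this estimate the expected step is a step that the limit leaves unreadable from compound 3 to compound 4.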

Compound 4, half-maximal inhibitory concentration: 42300 nM
Compound 4: middle estimate off by 14-fold (1.15 log units), on the high side, and the stated range ends above it.
By their numbers in this assay, from the lowest: compounds 4 and 1 (each within the scatter of the next); then compound 2. At a limit, above all of these: compound 3.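

In this assay, butyl in place of hydrogen on a saturated chain carbon, ten or more bonds along the chain from an amide-type nitrogen, brings an at least 9.4-fold lower number from compound 3 to compound 4 (0.97 log units; beyond the scatter), and hexyl in place of hydrogen at that place brings a 3.5-fold lower number from compound 2 to compound 4 (0.54 log units; beyond the scatter), so the number does not climb steadily with chain length across compound 2, compound 3 and compound 4. Compound 3 stands as a limit and not as a number in this assay: the limit of > 400000 nM in this assay, at which 1 of the 4 values shown sits. On the amine nitrogen, (furan-2-yl)carbonyl in place of hydrogen gives a 1.1-fold lower number from compound 1 to compound 4 (0.02 log units; within the scatter), so at this chain length the free amine and the acylated nitrogen cannot be told apart.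

Still open, going by these compounds, is how the number runs on chains lying between those of compound 3 and compound 4, or on a longer chain. Also open, on these data alone, is whether a free amine on a shorter chain, or a benzoyl group on that nitrogen, would follow the same course.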